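The source may hold more compounds than are shown below. What is called first, only, known or untested is meant among the compounds shown, and "the series" means these compounds.

Working notes on the series. Compound 1 `Cc1nc(-c2ccc(C(F)(F)F)cc2)sc1CNc1ccc(CCCC(=O)O)cc1` gives 44% in a functional assay on CHO cells for agonist activity at Free fatty acid receptor 1 (Homo sapiens), read by a luciferase reporter; on this read-out higher numbers stand for larger maximal responses and lower numbers for smaller maximal responses. Among the compounds with values here, compound 2 `Cc1nc(-c2ccc(C(F)(F)F)cc2)sc1CNc1ccc([C@H]2C[C@@H]2C(N)=O)cc1` gives 80% in this assay, and the single step measured so far, a number 36 percentage points higher from compound 1 to compound 2 (beyond the scatter), comes from replacing 3-carboxypropyl with 2-carbamoylcyclopropyl on an aromatic carbon. Within the data shown here, of the two numbers so far, compound 2 stands highest, with compound 1 the only neighbour and well beyond the scatter below it.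

Compound 3 `Cc1nc(-c2ccc(C(F)(F)F)cc2)sc1CNc1ccc([C@H]2C[C@@H]2C(=O)NO)cc1` keeps the shared core and the cyclopropyl of compound 2; the change is hydroxy in place of hydrogen on an amide-type nitrogen, so carbamoyl becomes hydroxycarbamoyl. Among the measured compounds shown here, no measured step touches this amide-type nitrogen: the step from compound 1 to compound 2 exchanged the whole side chain and does not tell how a hydroxy on that nitrogen acts. With nothing to go on, no step beyond the scatter is expected, and a shortfall is as plausible as a gain. Compound 3 is therefore expected to give 70%, within 45% to 90%, which would mean a step of a number 10 percentage points lower from compound 2 to compound 3 (within the scatter).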

Compound 3, largest response reached (reported as percent of maximum), in percent of the reference or control that the assay uses: 78%
Compound 3: the middle estimate sits 8 percentage points below what was measured, within the range that was stated.
By their numbers in this assay, from the lowest: compound 1; then compounds 3 and 2 (each within the scatter of the next).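

Hydroxy in place of hydrogen on the amide-type nitrogen gives a number 2 percentage points lower from compound 2 to compound 3 (within the scatter) in this assay, so this nitrogen carries the hydroxy with no step beyond the scatter. The exchange of 3-carboxypropyl for 2-(hydroxycarbamoyl)cyclopropyl on an aromatic carbon gives a number 34 percentage points higher from compound 1 to compound 3 (beyond the scatter) and thus shows that the large step up from compound 1 does not depend on the amide hydrogen being kept. No measurement at hand bears on the reason for either step.

The compounds shown leave open whether a methoxy on this nitrogen, or a carboxylic acid in place of the carbamoyl on the cyclopropyl, would hold the response at this level. They also leave open how much of the step from compound 1 belongs to the cyclopropyl and how much to the end group, which a straight chain ending in carbamoyl would separate.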